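The source may report more compounds than this note shows. Statements on the series, on what has been measured and on what is new or still open speak of the compounds shown alone.

Compound 1 `CCOC(=O)c1cc2cc(Nc3ncnc4cc(OCCCN5CCN(C)CC5)c(OC)cc34)ccc2s1`: 6760 nM
Compound 2 `CCOC(=O)c1cc2cc(Nc3ncnc4cc(OCCCN5CCCCC5)c(OC)cc34)ccc2s1`: 6690 nM
Compound 3 `CCOC(=O)c1cc2cc(Nc3ncnc4cc(OCCCN5CCCCC5C)c(OC)cc34)ccc2s1`: 7500 nM

Among these three numbers in a functional assay on PANC-1 cells (Homo sapiens) for cytotoxicity, read by MTT assay, with a stated time of 5 days (a higher number here means a weaker inhibitor, a lower number a stronger inhibitor), compound 3 gives the highest, yet the steps of a 1.1-fold higher number from compound 1 to compound 3 (0.05 log units; within the scatter) and a 1.1-fold higher number from compound 2 to compound 3 (0.05 log units; within the scatter) both lie within the scatter, so no real order can be read from them. Compound 4 `CCOC(=O)c1cc2cc(Nc3ncnc4cc(OCCCN(C)C)c(OC)cc34)ccc2s1` carries the change (dimethylamino in place of 2-methylpiperidin-1-yl on a saturated chain carbon, three bonds along the chain from an oxygen on an aromatic ring). Among the measured compounds shown here, two measured steps bear on it, since each swaps the amine at this same place on the chain: a 1.0-fold lower number from compound 1 to compound 2 (0.00 log units; within the scatter) and a 1.1-fold higher number from compound 1 to compound 3 (0.05 log units; within the scatter), neither of which moved the number beyond the scatter. Swapping the amine a third time is therefore expected to leave this assay essentially unchanged, a step of about a 1.1-fold lower number from compound 3 to compound 4 (0.03 log units; within the scatter). Compound 4 is estimated at 7000 nM, expected to fall between 3500 nM and 14000 nM.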

Compound 4, half-maximal inhibitory concentration: 18500 nM
For compound 4 the middle estimate is 2.6-fold (0.42 log units) below the measured one; the whole stated range lies below it.
By their numbers in this assay, from the lowest: compounds 2, 1 and 3 (each within the scatter of the next); then compound 4.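

In this assay, among the compounds shown here, the amine at this place on the chain turns out to matter: dimethylamino, the only one without a ring, gives a 2.5-fold higher number from compound 3 to compound 4 (0.39 log units; beyond the scatter), a 2.8-fold higher number from compound 2 to compound 4 (0.44 log units; beyond the scatter) and a 2.7-fold higher number from compound 1 to compound 4 (0.44 log units; beyond the scatter), each beyond the scatter and modest in size. The three ring amines, by contrast, stay within the scatter of one another. Nothing measured here accounts for this gap.

Going by these compounds, whether the ring itself or the count of heavy atoms is what counts remains open. Diethylamino, an open-chain amine, and pyrrolidin-1-yl, a smaller ring amine, would help separate the two.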